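The source may report more compounds than this note shows. Statements on the series, on what has been measured and on what is new or still open speak of the compounds shown alone.

Of the compounds shown here, three have been tested in a functional assay for inhibition of transient receptor potential cation channel subfamily V member 1 (Homo sapiens), read by fluorescence and calcium flux; on this read-out lower numbers stand for stronger inhibition and higher numbers for weaker inhibition.

Compound 1 `Cc1nc(O)c2cc(-c3ccc(Cl)c(OCC(=O)O)c3)c(C(C)C)cc2n1` gives > 1000 nM, which is a limit of this assay rather than a number.
Compound 2 `CC(C)c1cc2nc(N)nc(O)c2cc1-c1ccc(Cl)cc1` gives 133 nM.
Compound 3 `CCOc1cc(-c2cc3c(O)nc(C)nc3cc2C(C)C)ccc1Cl` gives 12 nM.

Compound 3 thus holds the lowest of the two numbers; compound 2 stands higher, and the gap between the two lies beyond the usual scatter. Compound 1 sits at the limit of > 1000 nM in this assay, at which 1 of the 3 values shown sits. For the measured compounds named here, the one step measured between compounds that differ in a single place runs from compound 1 to compound 3: an at least 83-fold lower number from compound 1 to compound 3 (1.92 log units; beyond the scatter), a large change at the chain carbon bound to the ring oxygen.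

Compound 4 `COCCOc1cc(-c2cc3c(O)nc(C)nc3cc2C(C)C)ccc1Cl` differs from compound 3 in one place: methoxy in place of hydrogen on a saturated chain carbon, two bonds along the chain from an oxygen on an aromatic ring. Going by the values given here, no measured step adds a methoxy at the end of such a chain, so the direction is open; the measured step concerned a carboxy, not a methoxy. Compound 4 is therefore expected to show a 2.1-fold higher number from compound 3 to compound 4 (0.32 log units; beyond the scatter). For compound 4 the estimate is 25 nM, expected to fall between 6 nM and 100 nM.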

Compound 4, half-maximal inhibitory concentration: 216 nM
Compound 4: middle estimate off by 8.6-fold (0.94 log units), on the low side; measured number above the stated range.
By their numbers in this assay, from the lowest: compound 3; then compounds 2 and 4 (each within the scatter of the next). At a limit, above all of these: compound 1.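

Adding a methoxy at the end of the ethoxy chain gives an 18-fold higher number from compound 3 to compound 4 (1.26 log units; beyond the scatter) in this assay, so this position responds strongly to a change that involves no carboxy group. The 2-methoxyethoxy chain still compares well with the carboxy-bearing chain of compound 1, with an at least 4.6-fold lower number from compound 1 to compound 4 (0.66 log units; beyond the scatter), which places compound 4 between the two ends of this short series, although the size of that step has only a bound. Compound 1 is held at a limit and not at a number: the limit of > 1000 nM in this assay, at which 1 of the 4 values shown sits.

The compounds shown leave open whether the higher number of compound 4 goes with the longer chain or with its added oxygen, a question that a plain propoxy chain would address. On these data alone, how an amine at the end of this chain would behave also remains open.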